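Chloro Added to the Indole of Compound 3

A few compounds are considered here, and "the series" means these few. Any claim that something is new, unique, unknown or untested is made for them only; others in the source may bear on it.

Measured so far in a functional assay on MV4-11 cells (Homo sapiens) for antiproliferative activity, read by CellTiter-Glo, with a stated time of 72 h; on this read-out lower numbers stand for stronger inhibition and higher numbers for weaker inhibition:
compound 1 `CO[C@@H]1[C@H](N(C)c2ncc(-c3c[nH]c4ccc(F)cc34)s2)C[C@H]2O[C@]1(C)n1c3ccccc3c3c4c(c5c6ccccc6n2c5c31)C(=O)NC4`, 510 nM
compound 2 `COc1ccc2[nH]cc(-c3cnc(N(C)[C@@H]4C[C@H]5O[C@@](C)([C@@H]4OC)n4c6ccccc6c6c7c(c8c9ccccc9n5c8c64)C(=O)NC7)s3)c2c1`, 360 nM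
compound 3 `CO[C@@H]1[C@H](N(C)c2ncc(-c3c[nH]c4ccccc34)s2)C[C@H]2O[C@]1(C)n1c3ccccc3c3c4c(c5c6cc(Cl)ccc6n2c5c31)C(=O)NC4`, 560 nM

Compound 3 sits within the scatter of both compound 1 and compound 2 in this assay, so the three numbers cannot be told apart. Compound 4 `CO[C@@H]1[C@H](N(C)c2ncc(-c3c[nH]c4ccc(Cl)cc34)s2)C[C@H]2O[C@]1(C)n1c3ccccc3c3c4c(c5c6cc(Cl)ccc6n2c5c31)C(=O)NC4` is not yet measured; it differs from compound 3 by chloro in place of hydrogen on an aromatic carbon. Among the measured compounds shown here, the only step measured at that same aromatic carbon is a 1.4-fold lower number from compound 1 to compound 2 (0.15 log units; within the scatter), which stayed inside the scatter, and compounds 1 and 3 differ in two places, so their values give no single-change reading. On this evidence no step beyond the scatter is expected, and compound 4 is estimated at 500 nM, between 250 nM and 1000 nM, which means an expected step of a 1.1-fold lower number from compound 3 to compound 4 (0.05 log units; within the scatter).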

Compound 4, half-maximal inhibitory concentration: 590 nM
Compound 4: middle estimate off by 1.2-fold (0.07 log units), on the low side; low and high end bracket the measured number.
By their numbers in this assay, from the lowest: compounds 2, 1, 3 and 4 (each within the scatter of the next).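

In this assay, the change from 1H-indol-3-yl to 5-chloro-1H-indol-3-yl gives a 1.1-fold higher number from compound 3 to compound 4 (0.02 log units; within the scatter). Among the compounds shown here, this is the first single-change reading at this carbon with hydrogen as the starting point, and like the exchange of fluoro for methoxy, a 1.4-fold lower number from compound 1 to compound 2 (0.15 log units; within the scatter), it stays inside the scatter. No measurement offers an explanation for this result.

Going by these compounds, whether an amine or a carboxylic acid on this carbon would move the number beyond the scatter remains open. The compounds shown also give no single-change reading of chloro here on a core without its other chloro.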